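The source may report more compounds than this note shows. Statements on the series, on what has been measured and on what is new or still open speak of the compounds shown alone.

In an ADME assay on HepG2 cells (Homo sapiens) for cytotoxicity, read by MTT assay, with a stated time of 72 h (a higher number here means that more compound is tolerated, a lower number that less compound is tolerated), compound 3 (`O=[N+]([O-])c1c(CS(=O)(=O)c2ccccc2)nc2c(-c3cccc(C(F)(F)F)c3)cc(Cl)cn12`) gives > 12500 nM as its result, which is a limit and not a number. Compound 1 (`O=[N+]([O-])c1c(CS(=O)(=O)c2ccccc2)nc2c(-c3cccc(F)c3)cc(Cl)cn12`) gives > 12500 nM which is likewise a limit. Compound 2 (`O=[N+]([O-])c1c(CS(=O)(=O)c2ccccc2)nc2c(-c3ccc(C(F)(F)F)cc3)cc(Cl)cn12`) gives > 3900 nM and this too is a limit. Compound 4 (`O=[N+]([O-])c1c(CS(=O)(=O)c2ccccc2)nc2c(-c3ccncc3)cc(Cl)cn12`) carries pyridin-4-yl in place of 3-(trifluoromethyl)phenyl on an aromatic carbon. The measured steps that bear on this change, a step that the two limits leave unreadable from compound 1 to compound 2 and a step that the two limits leave unreadable from compound 1 to compound 3 and a step that the two limits leave unreadable from compound 2 to compound 3 have no readable size. No step beyond the scatter is therefore expected in this assay in either direction. The estimated step is a step that the limit leaves unreadable from compound 3 to compound 4 and no more. Compound 4 is estimated at 16000 nM within an expected range of 5000 nM to 60000 nM and may again give only a limit.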

Compound 4, half-maximal cytotoxic concentration: > 50000 nM
Compound 4 ended at the assay's limit; the forecaster's own chance of this, stated with the estimate: 75%; at least 3.1-fold (0.49 log units) between middle value and limit.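

In this assay, among these compounds, compound 1, compound 2, compound 3 and compound 4 all give limits and not numbers, and no step among them can be read. From the compounds shown here alone, whether pyridin-4-yl changes tolerance at all stays open, as does the actual cytotoxic concentration of each compound.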